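Bromo to nitro on a shared core

This account rests on a few compounds, and the source may have more. Where it says the series, first, only, none or still open, it means among the compounds named here.

compound 1 `CC(C)(Oc1ccccc1O)C1OCC(C/C=C\CCC(=O)O)C(c2cccnc2)O1`: 95.5 nM
compound 2 `CC(C)(Oc1ccccc1Br)C1OCC(C/C=C\CCC(=O)O)C(c2cccnc2)O1`: 63.1 nM

For the measured compounds named here, in a functional assay for inhibition, with Homo sapiens as the target (a lower number here means tighter binding, a higher number weaker binding), compound 2 stands level with the only other measured compound. Compound 3 `CC(C)(Oc1ccccc1[N+](=O)[O-])C1OCC(C/C=C\CCC(=O)O)C(c2cccnc2)O1` carries nitro in place of bromo on an aromatic carbon, ortho to a large group (nitro in place of bromo on an aromatic carbon). Going by the values given here, the one measured step at this aromatic carbon, a 1.5-fold lower number from compound 1 to compound 2 (0.18 log units; within the scatter), exchanged hydroxy for bromo and stayed within the scatter. No shift beyond the scatter is therefore expected in this assay, though a single step is thin evidence. The expected step is a 1.3-fold higher number from compound 2 to compound 3 (0.10 log units; within the scatter). For compound 3 the estimated value is 80 nM, with an expected range of 28 nM to 230 nM.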

Compound 3, dissociation constant: 11.2 nM
For compound 3 the middle estimate is 7.1-fold (0.85 log units) above the measured one, and the stated range ends above it.
By their numbers in this assay, from the lowest: compound 3; then compounds 2 and 1 (each within the scatter of the next).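

In this assay this aromatic carbon proves sensitive to what it carries: replacing bromo with nitro gives a step beyond the scatter (a 5.6-fold lower number from compound 2 to compound 3 (0.75 log units; beyond the scatter)), and so does replacing hydroxy with nitro (an 8.5-fold lower number from compound 1 to compound 3 (0.93 log units; beyond the scatter)). The earlier exchange of hydroxy for bromo had stayed within the scatter, so among these three compounds only nitro stands apart. Nothing available here bears on why nitro does this.

The compounds shown leave open whether nitro is unique at this carbon or whether a nitrile or an amine would do the same. They also leave open whether the nitro step would hold on a different core.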